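Notes on the substituent on the ring amine nitrogen

This account rests on a few compounds, and the source may have more. Where it says the series, first, only, none or still open, it means among the compounds named here.

Measured so far:
compound 1 `CCCCCCN1CCN(CCC(=O)Nc2nc3c(C)cccc3s2)CC1`, 238 nM
compound 2 `Cc1cccc2sc(NC(=O)CCN3CCN(C4CCCCC4)CC3)nc12`, 24 nM

In an assay on membranes from brain for displacement of a labelled ligand from Sigma non-opioid intracellular receptor 1 (Cavia porcellus), read by scintillation counting, with a stated time of 120 min (a lower number here means a stronger inhibitor, a higher number a weaker inhibitor), compound 1 gives 238 nM, the highest of the two numbers; the nearest is compound 2, which gives 24 nM. Among the measured compounds shown here, the only measured step, a 9.9-fold lower number from compound 1 to compound 2 (1.00 log units; beyond the scatter), concerns a different entering group. Compound 3 `Cc1cccc2sc(NC(=O)CCN3CCN(c4ncccn4)CC3)nc12` differs from compound 1 as follows: pyrimidin-2-yl in place of hexyl on an amine nitrogen in a ring. For the measured compounds named here, no measured step brings in an aromatic ring at this place, so the cyclohexyl step bears only loosely here, and no step beyond the scatter is expected in this assay. Compound 3 is therefore estimated at 300 nM, between 70 nM and 1300 nM, an expected step of a 1.3-fold higher number from compound 1 to compound 3 (0.10 log units; within the scatter).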

Compound 3, inhibition constant: 505 nM
The estimate for compound 3 lay 1.7-fold (0.23 log units) below the measured number; measured number inside the range.
By their numbers in this assay, from the lowest: compound 2; then compound 1; then compound 3.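

In this assay, among the compounds shown here, the place on an amine nitrogen in a ring now carries an aromatic ring for the first time, and pyrimidin-2-yl gives the highest number of the three compounds, both in place of hexyl (a 2.1-fold higher number from compound 1 to compound 3 (0.33 log units; beyond the scatter)) and in place of cyclohexyl (a 21-fold higher number from compound 2 to compound 3 (1.32 log units; beyond the scatter)). Hexyl and pyrimidin-2-yl have the same count of heavy atoms, so that count alone does not set the number here. Nothing on hand accounts for these steps.

Open, going by these compounds, is whether a phenyl ring, which has carbon in place of the two ring nitrogens, would stand with pyrimidin-2-yl or nearer cyclohexyl. Also open, on these data alone, is how a benzyl group, or a smaller cyclopentyl ring, would compare with cyclohexyl at this place.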